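Two Small Changes on a Shared Benzylidene Scaffold

The source may hold more compounds than are shown below. What is called first, only, known or untested is meant among the compounds shown, and "the series" means these compounds.

Of the compounds shown here, three have been measured in a functional assay on A549 cells (Homo sapiens) for inhibition, read by sulforhodamine B assay; a higher number here means a weaker inhibitor of growth, a lower number a stronger inhibitor of growth. Compound 1 `CC(C)(C)c1ccc(OCc2ccccc2)c(/C=C2\SC(=S)NC2=O)c1` gives 7000 nM. Compound 2 `O=C1NC(=S)S/C1=C\c1cc(-c2ccccc2)ccc1OCc1ccccc1` differs from it by phenyl in place of tert-butyl on an aromatic carbon, and compound 2 gives 4000 nM, a step of a 1.8-fold lower number from compound 1 to compound 2 (0.24 log units; within the scatter). Compound 3 `CC(C)(C)c1ccc(OCc2ccccc2)c(/C=C2\SC(=O)NC2=O)c1` differs from compound 1 in its core, (a group of 8 heavy atoms (4 carbon, 1 nitrogen, 2 oxygen, 1 sulfur; one five-membered non-aromatic ring with 2 hetero atoms) in place of a group of 8 heavy atoms (4 carbon, 1 nitrogen, 1 oxygen, 2 sulfur; one five-membered non-aromatic ring with 2 hetero atoms), on an aromatic carbon), and compound 3 gives 2000 nM, a step of a 3.5-fold lower number from compound 1 to compound 3 (0.54 log units; beyond the scatter).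

Compound 4 `O=C1NC(=O)/C(=C/c2cc(-c3ccccc3)ccc2OCc2ccccc2)S1` is not yet measured. It differs from compound 3 by phenyl in place of tert-butyl on an aromatic carbon, the same change as from compound 1 to compound 2, made on the core of compound 3. From the earlier step of a 1.8-fold lower number from compound 1 to compound 2 (0.24 log units; within the scatter), the expected step for compound 4 is a 1.7-fold lower number from compound 3 to compound 4 (0.22 log units; within the scatter), resting on a single prior example. Compound 4 is therefore estimated at 1200 nM, between 500 nM and 3000 nM.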

Compound 4, concentration for 50% growth inhibition: 2000 nM
Estimate against measurement, compound 4: 1.7-fold (0.22 log units) below; low and high end bracket the measured number.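

Replacing tert-butyl with phenyl on the core of compound 3 gives no change at the digits printed from compound 3 to compound 4 (within the scatter), and this step does not differ beyond the scatter from the earlier one: the same change on two cores in this assay, a 1.8-fold lower number (0.24 log units; within the scatter) from compound 1 to compound 2 and no change at the digits printed (within the scatter) from compound 3 to compound 4, 1.8-fold (0.24 log units) apart, within the scatter of two such steps. Replacing the core with phenyl already in place gives a 2.0-fold lower number from compound 2 to compound 4 (0.30 log units; within the scatter), and this change also carries over without a difference beyond the scatter: the same change on two cores in this assay, a 3.5-fold lower number (0.54 log units; beyond the scatter) from compound 1 to compound 3 and a 2.0-fold lower number (0.30 log units; within the scatter) from compound 2 to compound 4, 1.8-fold (0.24 log units) apart, within the scatter of two such steps. For the compounds shown here, this shows that both changes behaved consistently across these four compounds, but with only one pair of steps for each change, it does not show that they would do so in other compounds, nor does it explain why.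

The compounds shown leave open what other groups on this aromatic carbon, such as an amine, a carboxylic acid or a longer chain, would do on either core.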